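Swapping a carbamate for an alkyl group on the ring nitrogen

A few compounds are considered here, and "the series" means these few. Any claim that something is new, unique, unknown or untested is made for them only; others in the source may bear on it.

Measured so far:
compound 1, `CC(C)S(=O)(=O)c1cnc(O[C@H]2CC[C@H](OC3CCN(C(=O)OC(C)(C)C)CC3)CC2)cn1`, 54 nM
compound 2, `C[C@@H](CF)OC(=O)N1CCC(O[C@H]2CC[C@H](Oc3cnc(S(C)(=O)=O)cn3)CC2)CC1`, 356 nM

In a functional assay on isolated protein for agonist activity at Glucose-dependent insulinotropic receptor (Rattus norvegicus), read by HTRF and cAMP accumulation (on this read-out lower numbers stand for an effect already at smaller amounts and higher numbers for an effect only at larger amounts of compound), compound 2 gives the higher of the two numbers, with compound 1 at 54 nM standing well apart from it. Compound 3, `CS(=O)(=O)c1cnc(O[C@H]2CC[C@H](OC3CCN(CC4(C(F)(F)F)CC4)CC3)CC2)cn1`, is not yet measured. It differs from compound 2 by a group of 8 heavy atoms (5 carbon, 3 fluorine; one three-membered non-aromatic ring of carbon only) in place of a group of 7 heavy atoms (4 carbon, 2 oxygen, 1 fluorine; no ring), on an amine nitrogen in a ring. Among the measured compounds shown here, no step of this kind has been measured in the set, so the expectation rests only on compound 2 and the size of the change. A small step is expected in this assay, from compound 2 to compound 3 of a 1.4-fold lower number from compound 2 to compound 3 (0.15 log units; within the scatter), in either direction and likely within the scatter. Compound 3 is therefore estimated at 250 nM, between 60 nM and 1200 nM.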

Compound 3, half-maximal effective concentration: 163 nM
The estimate for compound 3 lay 1.5-fold (0.19 log units) above the measured number, within the range that was stated.
By their numbers in this assay, from the lowest: compound 1; then compound 3; then compound 2.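

In this assay the ring nitrogen does not need a carbamate: putting (1-(trifluoromethyl)cyclopropyl)methyl there gives a 2.2-fold lower number from compound 2 to compound 3 (0.34 log units; beyond the scatter). This position therefore accepts an alkyl group with no hydrogen-bond acceptors in place of a carbamate group with two, without any loss in this read-out. Nothing measured here explains the modest gain.

Going by these compounds, whether the trifluoromethyl is needed remains open, and a plain cyclopropylmethyl group would test that. On these data alone, an amide or a urea on the same nitrogen also remains untested.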